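Fluoro for Methyl on the Phenylcarbonyl of Compound 1

The source may hold more compounds than are shown below. What is called first, only, known or untested is meant among the compounds shown, and "the series" means these compounds.

Compound 1 `CCN1CCN(c2cc(C)c3cc(NC(=O)c4cccc(C)c4)ccc3n2)CC1` is tested in a functional assay on MCF7 cells (Homo sapiens) for antiproliferative activity, read by MTT assay, with a stated time of 72 h (a lower number here means a stronger inhibitor, a higher number a weaker inhibitor), where compound 1 gives 7800 nM. Of the two numbers recorded in this assay, that of compound 1 is the higher; the nearest is compound 3 `Cc1cc(N2CCN(C)CC2)nc2ccc(NC(=O)c3ccc(Cl)c(Cl)c3)cc12`, which gives 3000 nM. Compound 2 `CCN(CC)c1cc(C)c2cc(NC(=O)c3ccc(Cl)c(Cl)c3)ccc2n1` gives only a limit of the assay, > 50000 nM (the limit of > 50000 nM in this assay, at which 1 of the 3 values shown sits). Within the data shown here, the single measured step, an at least 16-fold lower number from compound 2 to compound 3 (1.22 log units; beyond the scatter), concerns the amine on the shared core rather than the phenylcarbonyl. Compound 4 `CCN1CCN(c2cc(C)c3cc(NC(=O)c4cccc(F)c4)ccc3n2)CC1` differs from compound 1 by fluoro in place of methyl on an aromatic carbon. Among the measured compounds shown here, no measured step touches this part of the molecule, so nothing beyond the scatter is expected, and compound 4 is estimated at 7000 nM, between 3000 nM and 16000 nM, an expected step of a 1.1-fold lower number from compound 1 to compound 4 (0.05 log units; within the scatter).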

Compound 4, half-maximal inhibitory concentration: 8920 nM
The estimate for compound 4 lay 1.3-fold (0.11 log units) below the measured number; low and high end bracket the measured number.
By their numbers in this assay, from the lowest: compound 3; then compounds 1 and 4 (each within the scatter of the next). At a limit, above all of these: compound 2.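

In this assay, among these compounds, fluoro in place of methyl on this aromatic carbon gives a 1.1-fold higher number from compound 1 to compound 4 (0.06 log units; within the scatter), the only measured step on the phenylcarbonyl part of the molecule. Among the compounds shown here, this position therefore tolerates the exchange of 3-methylphenyl for 3-fluorophenyl without a change beyond the scatter, whereas the one earlier step concerned the amine on the shared core. Nothing recorded here gives a reason for this outcome. Going by these compounds, whether an amine, a carboxylic acid or a longer chain at this position would shift the number remains open. So does whether fluoro elsewhere on this ring would behave alike.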